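The compounds below may be only part of what the source reports. "The series", "measured", "known", "first", "only" and "open" are said of these compounds alone.

In a functional assay on HeLa cells (Homo sapiens) for inhibition, read by MTT assay, with a stated time of 72 h (a lower number here means a stronger inhibitor, a higher number a weaker inhibitor), compound 3 `COc1cc(NC(C)CCCNC(=O)Nc2ccc(Cl)cc2)c2ncccc2c1` gives 18000 nM as the lowest of the numbers shown, which makes it the strongest inhibitor of the three measured compounds. Compound 1 `COc1cc(NC(C)CCCNC(=O)NNC(=O)Nc2ccc(Cl)cc2)c2ncccc2c1` gives 120000 nM as its number. Compound 2 `COc1cc(NC(C)CCCNC(=O)NNC(=O)Nc2cccc(F)c2)c2ncccc2c1` gives > 250000 nM as a limit of the assay and not a number.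

Compound 4 `COc1cc(NC(C)CCCNC(=O)NNC(=O)Nc2cccc(Cl)c2)c2ncccc2c1` has not yet been measured. It differs from compound 3 on an amide-type nitrogen whose other neighbour is a carbonyl carbon, where ((3-chlorophenyl)carbamoyl)amino stands in place of 4-chlorophenyl (((3-chlorophenyl)carbamoyl)amino in place of 4-chlorophenyl on an amide-type nitrogen). The reverse kind of swap has been measured twice, as a 6.7-fold lower number from compound 1 to compound 3 (0.82 log units; beyond the scatter) and as an at least 13-fold lower number from compound 2 to compound 3 (1.14 log units; beyond the scatter) in a case resting on a limit. Changing only the ring group gave an at least 2.0-fold higher number from compound 1 to compound 2 (0.31 log units; beyond the scatter) as a further guide. Compound 4 is therefore expected to sit well above compound 3 and near compound 1, with the estimated step being an 8.3-fold higher number from compound 3 to compound 4 (0.92 log units; beyond the scatter) in this assay terms. The estimated value for compound 4 is 150000 nM with 70000 nM to 300000 nM as its expected range.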

Compound 4, half-maximal inhibitory concentration: 44000 nM
Estimate against measurement, compound 4: 3.4-fold (0.53 log units) above; measured number below the stated range.
By their numbers in this assay, from the lowest: compound 3; then compound 4; then compound 1. At a limit, above all of these: compound 2.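

Changes on the ring alone matter more than the earlier compounds showed: with 3-chlorophenyl in place of 4-chlorophenyl, this assay gives a 2.7-fold lower number from compound 1 to compound 4 (0.44 log units; beyond the scatter), and with chloro in place of fluoro it gives an at least 5.6-fold lower number from compound 2 to compound 4 (0.75 log units; beyond the scatter). That second step has only a bound, since compound 2 stands at a limit of the assay and not a number: the limit of > 250000 nM in this assay, at which 1 of the 4 values shown sits. The ((3-chlorophenyl)carbamoyl)amino group still gives a 2.4-fold higher number from compound 3 to compound 4 (0.39 log units; beyond the scatter), a smaller cost than the one seen with the other two ring groups, so the cost of this longer group depends on the ring it carries.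

From the compounds shown here alone, what 3-chlorophenyl would give in the place of 4-chlorophenyl in compound 3 stays open. So does the effect of a bromo or methoxy group on the ring, or of a longer chain.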